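A few compounds are considered here, and "the series" means these few. Any claim that something is new, unique, unknown or untested is made for them only; others in the source may bear on it.

Of the compounds shown here, three that share one core have so far been measured in a functional assay for inhibition of nuclear factor NF-kappa-B complex (Homo sapiens); on this read-out lower numbers stand for stronger inhibition and higher numbers for weaker inhibition. Compound 1 `COc1ccc2c(c1)OC(c1cc(OC)c(OC)c(OC)c1)C(C(=O)NC(C)(C)C)=C2` carries a (tert-butyl)carbamoyl group on a double-bonded ring carbon, and in this assay compound 1 gives 28400 nM. Compound 2 `COc1ccc2c(c1)OC(c1cc(OC)c(OC)c(OC)c1)C(C=O)=C2` carries a formyl group on the same double-bonded ring carbon, and compound 2 gives 13500 nM. Compound 3 `CCOCC1=Cc2ccc(OC)cc2OC1c1cc(OC)c(OC)c(OC)c1` carries an ethoxymethyl group there, and compound 3 gives 21300 nM. Among the three numbers compound 3 stands second highest, closest to compound 1, and both of its gaps stay within the scatter. Among the compounds with values here, only one step is beyond the scatter: a 2.1-fold lower number from compound 1 to compound 2 (0.32 log units; beyond the scatter). The two steps that end at compound 3, a 1.3-fold lower number from compound 1 to compound 3 (0.12 log units; within the scatter) and a 1.6-fold higher number from compound 2 to compound 3 (0.20 log units; within the scatter), are within it.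

Compound 4 `COc1ccc2c(c1)OC(c1cc(OC)c(OC)c(OC)c1)C(C(=O)N(C)C)=C2` has not yet been measured. It differs from compound 3 by dimethylcarbamoyl in place of ethoxymethyl on a double-bonded ring carbon. Within the data shown here, the steps that bear on this are those involving the same double-bonded ring carbon: the exchange of a carbamoyl for ethoxymethyl in a 1.3-fold lower number from compound 1 to compound 3 (0.12 log units; within the scatter) was within the scatter, as was a 1.6-fold higher number from compound 2 to compound 3 (0.20 log units; within the scatter). Because a 1.3-fold lower number from compound 1 to compound 3 (0.12 log units; within the scatter) was so small, compound 4 is expected to show no step beyond the scatter, a 1.1-fold lower number from compound 3 to compound 4 (0.03 log units; within the scatter). The estimate for compound 4 is 20000 nM, with a range from 8000 nM to 50000 nM.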

Compound 4, half-maximal inhibitory concentration: > 50000 nM
Compound 4: a limit, no number (the forecaster's own chance of this, stated with the estimate: 10%); middle value at least 2.5-fold (0.39 log units) from the limit.
By their numbers in this assay, from the lowest: compounds 2, 3 and 1 (each within the scatter of the next, the first and the last beyond it). At a limit, above all of these: compound 4.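

In this assay compound 4 stands at a limit of the assay and not at a number: the limit of > 50000 nM in this assay, at which 1 of the 4 values shown sits. At this double-bonded ring carbon, the exchange of ethoxymethyl for dimethylcarbamoyl gives an at least 2.3-fold higher number from compound 3 to compound 4 (0.37 log units; beyond the scatter), and the comparison with the formyl compound gives an at least 3.7-fold higher number from compound 2 to compound 4 (0.56 log units; beyond the scatter), so the group at this position can move the read-out beyond the scatter even where the earlier exchange of (tert-butyl)carbamoyl for ethoxymethyl did not. The two carbamoyl compounds remain unseparated, since the step between them gives an at least 1.7-fold higher number from compound 1 to compound 4 (0.24 log units; that floor lies within the scatter), which leaves the real distance between them unresolved.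

The compounds shown leave open how far beyond its limit compound 4 lies, and therefore whether the change from the (tert-butyl)amino to the dimethylamino carbonyl has any real effect in this assay. They also leave open how a methylcarbamoyl group, an unsubstituted carbamoyl group, a hydroxymethyl group or a carboxylic acid at this ring carbon would read, and whether any of these would give a lower number than the formyl group of compound 2.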